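Straight aminoalkyl chain replaces branched amine on the ether

The compounds below may be only part of what the source reports. "The series", "measured", "known", "first", "only" and "open" are said of these compounds alone.

Compounds 1, 2 and 3 share one core and differ only in the group on an oxygen on an aromatic ring. In an ADME assay on microsomes from liver (Homo sapiens) for metabolic stability, read by LC-MS, tested at 1 uM (a lower number here means slower removal, a higher number faster removal of the compound), compound 1 `CC(C)(O)CN1CCC(Oc2ccc([C@H]3CC[C@]4(CC3)OOC3(O4)C4CC5CC(C4)CC3C5)cc2)CC1` gives 18 mL.min-1.g-1. Compound 2 `c1cc([C@H]2CC[C@]3(CC2)OOC2(O3)C3CC4CC(C3)CC2C4)ccc1OCC1CCNCC1` gives < 7 mL.min-1.g-1 in this assay, which is a limit of the assay. Compound 3 `CC(C)(CN)Oc1ccc([C@H]2CC[C@]3(CC2)OOC2(O3)C3CC4CC(C3)CC2C4)cc1` likewise gives < 7 mL.min-1.g-1 in this assay, again a limit. Compound 3 therefore stands at the limit of < 7 mL.min-1.g-1 in this assay, at which 2 of the 3 values shown sit. The step of an at least 2.5-fold lower number from compound 1 to compound 3 (0.41 log units; beyond the scatter) is readable, whereas the step that the two limits leave unreadable from compound 2 to compound 3 is not. Compound 4 `NCCCCCOc1ccc([C@H]2CC[C@]3(CC2)OOC2(O3)C3CC4CC(C3)CC2C4)cc1` is not yet measured; it differs from compound 3 by 5-aminopentyl in place of 1-(aminomethyl)-1-methylethyl on an oxygen on an aromatic ring. Because compound 3 sits at the limit of < 7 mL.min-1.g-1 in this assay, at which 2 of the 3 values shown sit, only a small step, if any, is expected, a number no lower from compound 3 to compound 4 (the limit leaves the size open). Compound 4 is estimated at 7 mL.min-1.g-1, in the range 3 mL.min-1.g-1 to 15 mL.min-1.g-1.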

Compound 4, intrinsic clearance in microsomes: < 7 mL.min-1.g-1
Compound 4: only a limit was reported; the forecaster's own chance of this, stated with the estimate: 55%; the middle value lies on the limit itself.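

In this assay, the straight 5-aminopentyl chain on the oxygen reads no differently from the two shorter or ring-bearing amine groups, since compound 4 also gives only a limit: (the limit of < 7 mL.min-1.g-1 in this assay, at which 3 of the 4 values shown sit). The chain with no ring and no branch still gives an at least 2.5-fold lower number from compound 1 to compound 4 (0.41 log units; beyond the scatter) and so matches compound 2 and compound 3 in this. Among these compounds, compound 1 remains the only compound with a value that is not a limit.

As far as these compounds go, the steps among compound 2, compound 3 and compound 4 cannot be read, so their order stays open. Also open, from the compounds shown here alone, is how a carboxylic acid or a plain pentyl chain on this oxygen would behave.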